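The compounds below may be only part of what the source reports. "The series", "measured", "known", "first", "only" and "open" are said of these compounds alone.

Measured so far in a functional assay on HepG2 cells (Homo sapiens) for cytotoxicity, read by MTT assay, with a stated time of 48 h; a higher number here means a weaker inhibitor, a lower number a stronger inhibitor:
compound 1 `Cc1ncc([N+](=O)[O-])n1CCSc1nnc(-c2ccc(N)cc2)o1` gives 6700 nM;
compound 2 `CCOc1ccc(-c2nnc(SCCn3c([N+](=O)[O-])cnc3C)o2)cc1` gives 1900 nM;
compound 3 `COc1ccc(-c2nnc(SCCn3c([N+](=O)[O-])cnc3C)o2)c(O)c1` gives 11000 nM.

Among these three numbers compound 1 sits second highest. Among the measured compounds shown here, its value and that of compound 3 lie within the scatter of each other, while the single measured step, a 3.5-fold lower number from compound 1 to compound 2 (0.55 log units; beyond the scatter), sets compound 2 apart. Compound 4 `Cc1ncc([N+](=O)[O-])n1CCSc1nnc(-c2ccc(N)nc2)o1` differs from compound 1 in one place: 6-aminopyridin-3-yl in place of 4-aminophenyl on an aromatic carbon. For the measured compounds named here, no measured step concerns a change of this kind; the only step available swaps amino for ethoxy on the same ring, a different alteration, so it offers no guide here. The expected step is therefore one of no clear size in either direction, a 1.0-fold higher number from compound 1 to compound 4 (0.02 log units; within the scatter). Compound 4 is accordingly estimated at 7000 nM, within a range of 2500 nM to 20000 nM.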

Compound 4, half-maximal inhibitory concentration: 9400 nM
The estimate for compound 4 lay 1.3-fold (0.13 log units) below the measured number, within the range that was stated.
By their numbers in this assay, from the lowest: compound 2; then compounds 1, 4 and 3 (each within the scatter of the next).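

Putting 6-aminopyridin-3-yl in place of 4-aminophenyl gives a 1.4-fold higher number from compound 1 to compound 4 (0.15 log units; within the scatter) in this assay. A ring nitrogen can therefore enter this aromatic ring, with the amino group kept, without a change that stands out from the scatter. Nothing at hand explains this result.

Going by these compounds, it remains open whether the ethoxy group of compound 2 would give a lower number on the ring of compound 4 as well. A carboxylic acid or a dimethylamino group in place of the amino group also remains untested among the compounds shown.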